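Swapping an amine linker for an oxadiazole ether

A few compounds are considered here, and "the series" means these few. Any claim that something is new, unique, unknown or untested is made for them only; others in the source may bear on it.

Of the compounds shown here, two of a shared core have been measured in an ADME assay on HEK293 cells (Homo sapiens) for cytotoxicity, read by ATP content, with a stated time of 6 h; on this read-out lower numbers stand for higher toxicity in this test and higher numbers for lower toxicity in this test. Compound 1, `CCCCNc1nc(N)nc2ccn(Cc3cn4ccccc4n3)c12`, gives in this assay > 24000 nM, which is a limit of the assay rather than a number. Compound 2, `COCCCNc1nc(N)nc2ccn(Cc3ccccn3)c12`, likewise gives in this assay > 24000 nM, again a limit and not a number. So compound 2 stands where the only other measured compound stands: at the limit of > 24000 nM in this assay, at which 2 of the 2 values shown sit, with no finite value for either of them and no measured step between them.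

Compound 3, `Cc1nc(COc2nc(N)nc3ccn(Cc4ccccn4)c23)no1`, has not yet been measured in this assay. It differs from compound 2 in one place: (5-methyl-1,2,4-oxadiazol-3-yl)methoxy in place of (3-methoxypropyl)amino on an aromatic carbon. Going by the values given here, the change removes the only hydrogen-bond donor of that group and brings in a small aromatic ring, yet there is no measured step in this assay to show what such a change does here.

Since the measured values sit at the limit, compound 3 is expected to show a step that the limit leaves unreadable from compound 2 to compound 3 of none beyond the scatter. Compound 3 is therefore expected to give about 30000 nM in this assay, most likely between 10000 nM and 90000 nM, and most likely reported only as a limit.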

Compound 3, half-maximal cytotoxic concentration: > 24000 nM
Compound 3: no number, only a limit; the forecaster's own chance of this, stated with the estimate: 75%; the middle value does not contradict the limit.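

In this assay, going by these compounds alone, compound 3 sits at the same limit of the assay as compound 2, and no step between the two can be read. The compounds shown leave open whether (5-methyl-1,2,4-oxadiazol-3-yl)methoxy in place of (3-methoxypropyl)amino changes the half-maximal cytotoxic concentration at all, and in which direction.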